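The compounds below may be only part of what the source reports. "The series", "measured", "known", "first", "only" and "open" are said of these compounds alone.

Measured compounds and their values:

compound 1 `O=C(Nc1ccc(Cl)cc1)Nc1cccc(CNc2nccnc2Cl)c1` — 8350 nM
compound 2 `CN(C)c1ccc(NC(=O)Nc2cccc(CNc3nccnc3Cl)c2)cc1` — > 40000 nM
compound 3 `Cc1cccc(NC(=O)Nc2cccc(CNc3nccnc3Cl)c2)c1` — 11200 nM

In a functional assay on HepG2 cells (Homo sapiens) for antiproliferative activity, read by MTT assay, with a stated time of 48 h (on this read-out lower numbers stand for stronger inhibition and higher numbers for weaker inhibition), compound 1 gives 8350 nM, the lowest of the two numbers shown. Compound 3 gives 11200 nM, and the step of a 1.3-fold higher number from compound 1 to compound 3 (0.13 log units; within the scatter) stays within the scatter. For compound 2 the value is a limit of the assay and not a number (the limit of > 40000 nM in this assay, at which 1 of the 3 values shown sits). Replacing chloro by dimethylamino on an aromatic carbon gives an at least 4.7-fold higher number from compound 1 to compound 2 (0.68 log units; beyond the scatter), and from compound 2 to compound 3 the step is an at least 3.5-fold lower number from compound 2 to compound 3 (0.55 log units; beyond the scatter).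

Compound 4 `CCc1ccccc1NC(=O)Nc1cccc(CNc2nccnc2Cl)c1` differs from compound 1 by 2-ethylphenyl in place of 4-chlorophenyl on an amide-type nitrogen. The step that bears on it is the exchange of the whole aryl group on the amide-type nitrogen, seen in a 1.3-fold higher number from compound 1 to compound 3 (0.13 log units; within the scatter), which stayed within the scatter. A 2-ethylphenyl group has not been measured here, so the expectation for compound 4 rests on that one step alone and is expected to be a 1.2-fold higher number from compound 1 to compound 4 (0.08 log units; within the scatter), no change beyond the scatter. Compound 4 is therefore estimated at 10000 nM, with a range from 4000 nM to 30000 nM.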

Compound 4, half-maximal inhibitory concentration: 7860 nM
Estimate against measurement, compound 4: 1.3-fold (0.10 log units) above; the measured number falls inside the stated range.
By their numbers in this assay, from the lowest: compounds 4, 1 and 3 (each within the scatter of the next). At a limit, above all of these: compound 2.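

In this assay, 2-ethylphenyl on the amide-type nitrogen reads level with 4-chlorophenyl, at a 1.1-fold lower number from compound 1 to compound 4 (0.03 log units; within the scatter), and with 3-methylphenyl, at a 1.4-fold lower number from compound 3 to compound 4 (0.15 log units; within the scatter), so three different aryl groups now give values within the scatter of one another. The 4-(dimethylamino)phenyl group of compound 2 is the one exception among the compounds shown, at an at least 5.0-fold lower number from compound 2 to compound 4 (0.70 log units; beyond the scatter). The value of compound 2 is a limit and not a number: the limit of > 40000 nM in this assay, at which 1 of the 4 values shown sits.

Group and ring place change together between compound 1 and compound 4, so neither can be judged alone from these values. As far as these compounds go, whether a primary amine or a carboxylic acid on the phenyl group would track with compound 2, and whether a chain longer than ethyl would hold the level of compound 4, stays open.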